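Swapping the aminotriazole: a triazolinone analogue in compound 4

The source may report more compounds than this note shows. Statements on the series, on what has been measured and on what is new or still open speak of the compounds shown alone.

Measured compounds:
compound 1 `CCC(C)(C)Cc1c[nH]c(CCc2ccc(-c3ccccc3O)cc2)n1`, 31 nM
compound 2 `CCC(C)(C)Cc1c[nH]c(CCc2ccc(-c3ccccc3OCC(=O)O)cc2)n1`, 103 nM
compound 3 `CCC(C)(C)Cc1c[nH]c(CCc2ccc(-c3ccccc3OCc3nc(N)n[nH]3)cc2)n1`, 27 nM

In an assay on isolated protein for binding affinity to Bombesin receptor subtype-3 (Homo sapiens) (on this read-out lower numbers stand for stronger inhibition and higher numbers for weaker inhibition), compound 3 gives the lowest number of the three, but its gap to compound 1, a 1.1-fold lower number from compound 1 to compound 3 (0.06 log units; within the scatter), is within the scatter, so the two are not separated; against compound 2 it stands clearly apart, with a 3.8-fold lower number from compound 2 to compound 3 (0.58 log units; beyond the scatter). Compound 4 `CCC(C)(C)Cc1c[nH]c(CCc2ccc(-c3ccccc3OCc3nc(=O)[nH][nH]3)cc2)n1` has not been measured. It differs from compound 3 in one place: a group of 6 heavy atoms (2 carbon, 3 nitrogen, 1 oxygen; one five-membered aromatic ring with 3 hetero atoms) in place of a group of 6 heavy atoms (2 carbon, 4 nitrogen; one five-membered aromatic ring with 3 hetero atoms), on a saturated chain carbon bound to an oxygen on an aromatic ring.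

Within the data shown here, two measured steps bear on this position. Replacing hydrogen on the aromatic oxygen with carboxymethyl gave a 3.3-fold higher number from compound 1 to compound 2 (0.52 log units; beyond the scatter), while the (3-amino-1H-1,2,4-triazol-5-yl)methyl group gave a 1.1-fold lower number from compound 1 to compound 3 (0.06 log units; within the scatter). The exchange in compound 4 keeps a five-membered aromatic ring with three hetero atoms on the same saturated chain carbon, so a step of the size seen between compound 2 and compound 3 seems less likely than a small one. Compound 4 is therefore expected to show a 1.5-fold higher number from compound 3 to compound 4 (0.17 log units; within the scatter) in this assay, with an estimate of 40 nM and a range from 15 nM to 110 nM.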

Compound 4, half-maximal inhibitory concentration: 31 nM
Compound 4: the middle estimate sits 1.3-fold (0.11 log units) above what was measured; the measured number falls inside the stated range.
By their numbers in this assay, from the lowest: compounds 3, 1 and 4 (each within the scatter of the next); then compound 2.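

In this assay the triazolinone ring of compound 4 is not separated from the aminotriazole of compound 3, with a 1.1-fold higher number from compound 3 to compound 4 (0.06 log units; within the scatter) as the step, so at this position the amino group can be exchanged for a ring carbonyl without a readable difference. Among these compounds, compound 4 also stands clear of the carboxymethyl compound, with a 3.3-fold lower number from compound 2 to compound 4 (0.52 log units; beyond the scatter) as the step, so compound 3 is no longer the only compound with a five-membered ring on this chain carbon to do so. With no change at the digits printed from compound 1 to compound 4 (within the scatter) as the step, this second ring likewise adds nothing readable over the hydrogen on the aromatic oxygen. No evidence is available to explain these results. On these data alone, whether a tetrazole or a primary amide on the same carbon, or a longer chain carrying the triazolinone, would stay within this range remains open.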